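The source may hold more compounds than are shown below. What is called first, only, known or untested is meant among the compounds shown, and "the series" means these compounds.

Of the compounds shown here, three built on one shared core have been measured in an assay on FRT-Jurkat cells for inhibition of nuclear factor NF-kappa-B complex (Homo sapiens), read by flow cytometry, with a stated time of 24 h, tested at 10 uM; on this read-out higher numbers stand for more inhibition at the one concentration tested (going by the name of the read-out) and lower numbers for less inhibition. Compound 3 `Cc1ccc(Nc2cccc3c2C(=O)N(C2CCC(=O)NC2=O)C3=O)cc1` gives 9%, the second highest of the three numbers. Compound 1 `CCCc1ccc(Nc2cccc3c2C(=O)N(C2CCC(=O)NC2=O)C3=O)cc1` gives 23%, and compound 2 `O=C1CCC(N2C(=O)c3cccc(Nc4ccccc4)c3C2=O)C(=O)N1` gives 4%. The steps between them are a number 19 percentage points lower from compound 1 to compound 2 (beyond the scatter), a number 14 percentage points lower from compound 1 to compound 3 (beyond the scatter) and a number 5 percentage points higher from compound 2 to compound 3 (within the scatter).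

Compound 4 `C=C(OCC)c1ccc(Nc2cccc3c2C(=O)N(C2CCC(=O)NC2=O)C3=O)cc1` differs from compound 3 in a single place: 1-ethoxyethenyl in place of methyl on an aromatic carbon. The measured steps that bear on this are those that alter the group on that same aromatic carbon, namely a number 5 percentage points higher from compound 2 to compound 3 (within the scatter) and a number 14 percentage points lower from compound 1 to compound 3 (beyond the scatter). Across these three compounds the larger group on that carbon went with the higher number, compound 1 with its propyl standing highest, and no measured compound goes against this. Among the compounds with values here, on that basis the step of a number 9 percentage points higher from compound 3 to compound 4 (within the scatter) is expected to be a modest rise, though with only three compounds behind it the expectation carries real uncertainty. Compound 4 is therefore estimated at 18%, with a range from 5% to 32%.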

Compound 4, a percentage reported as inhibition, at one concentration (the size of the read-out at that concentration, not a potency): 10%
Estimate against measurement, compound 4: 8 percentage points above, and the stated range covers the measured number.
By their numbers in this assay, from the lowest: compounds 2, 3 and 4 (each within the scatter of the next); then compound 1.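

Replacing methyl with 1-ethoxyethenyl brings in more heavy atoms, a double bond and a hydrogen-bond acceptor, yet the result is a number 1 percentage points higher from compound 3 to compound 4 (within the scatter), and against plain hydrogen on this aromatic carbon it is a number 6 percentage points higher from compound 2 to compound 4 (within the scatter), so added size alone does not raise the number at this position. Within the data shown here, the propyl group still stands apart, with a number 13 percentage points lower from compound 1 to compound 4 (beyond the scatter), which leaves it as the only group here that lifts the number beyond the scatter. No data are available to explain why this branched, oxygen-bearing group behaves differently from propyl.

As far as these compounds go, it remains open whether a longer saturated chain such as butyl would raise the number further. From the compounds shown here alone, it is equally open whether a plain ethoxy group or an amine on this carbon would behave like propyl or like methyl.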